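The compounds below may be only part of what the source reports. "The series", "measured", "known", "first", "only" and "open" are said of these compounds alone.

Measured compounds in a functional assay on L1210 cells (Mus musculus) for inhibition; on this read-out higher numbers stand for weaker inhibition and lower numbers for stronger inhibition:
- compound 1 `CCCCNC(=O)OC/C=C(\C)C1=CC(=O)C(C)(C)O1`: 2.6 ug/mL
- compound 2 `C/C(=C\COC(=O)NC(C)C)C1=CC(=O)C(C)(C)O1`: 4.9 ug/mL
- compound 3 `C/C(=C\C=C\c1ccccc1)C1=CC(=O)C(C)(C)O1`: 14 ug/mL

Compound 2 stands second highest of the three numbers in this assay; its nearest neighbour is compound 1, and the two differ by a 1.9-fold higher number from compound 1 to compound 2 (0.28 log units; within the scatter), so the pair is not told apart. Within the data shown here, compound 3 lies furthest from compound 2; the gap between the two values is beyond the scatter, but compound 3 also lacks the carbamate chain of compound 2 and no single-place step connects them.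

The unmeasured compound 4 `C/C(=C\COC(=O)NCc1ccccc1)C1=CC(=O)C(C)(C)O1` differs from compound 2 by benzyl in place of isopropyl on an amide-type nitrogen. Among the measured compounds shown here, the only measured step on the same nitrogen is the one from compound 1 to compound 2, which was within the scatter. For the measured compounds named here, no measured step covers an aromatic ring at this position, so the expectation rests on that single alkyl-to-alkyl step. A step of no more than the scatter is expected, with no clear direction; the estimated step is a 1.2-fold lower number from compound 2 to compound 4 (0.09 log units; within the scatter). For compound 4 this assay is expected to give about 4 ug/mL, within 1.5 ug/mL to 12 ug/mL.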

Compound 4, half-maximal inhibitory concentration: 4.7 ug/mL
The estimate for compound 4 lay 1.2-fold (0.07 log units) below the measured number; measured number inside the range.
By their numbers in this assay, from the lowest: compounds 1, 4 and 2 (each within the scatter of the next); then compound 3.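

Among these compounds, on the amide-type nitrogen, benzyl in place of isopropyl brings one six-membered aromatic ring to a position that held only open alkyl chains in the earlier compounds, and in this assay the step is a 1.0-fold lower number from compound 2 to compound 4 (0.02 log units; within the scatter) and so leaves the pair not told apart. The comparison with the butyl compound gives a 1.8-fold higher number from compound 1 to compound 4 (0.26 log units; within the scatter) and is equally unresolved, so this read-out separates none of butyl, isopropyl and benzyl at this nitrogen, and the aromatic ring brings no measurable change here. No available measurement bears on why these three groups read alike.

Still open, on these data alone, is whether a group of another kind on this nitrogen, such as an amine-bearing chain or a carboxylic acid, would give a step beyond the scatter. Also open, as far as these compounds go, is what replacing the amide hydrogen with a methyl group would do.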